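A few compounds are considered here, and "the series" means these few. Any claim that something is new, unique, unknown or untested is made for them only; others in the source may bear on it.

Compound 1, whose structure is `CN(C)C(=O)CN1CCC(c2cc3c(-c4ccc(=O)n(C)c4)ccnc3[nH]2)CC1`, was tested in an ADME assay on microsomes from liver (Homo sapiens) for metabolic stability; on this read-out lower numbers stand for slow clearance and higher numbers for fast clearance. There compound 1 gives < 3 uL/min, which is a limit of the assay rather than a number. Two related compounds alter the same ring on the core. Compound 2 `COc1cc(F)ccc1-c1ccnc2[nH]c(C3CCN(CC(=O)N(C)C)CC3)cc12` gives 14 uL/min in this assay. Compound 3 `CC(C)n1cc(-c2ccnc3[nH]c(C4CCN(CC(=O)N(C)C)CC4)cc23)cnc1=O` gives 24 uL/min in this assay. The step of an at least 4.6-fold higher number from compound 1 to compound 2 (0.66 log units; beyond the scatter) and the step of an at least 8.0-fold higher number from compound 1 to compound 3 (0.90 log units; beyond the scatter) both swap out the whole ring; between them, a 1.7-fold higher number from compound 2 to compound 3 (0.23 log units; within the scatter). Compound 4 `CN(C)C(=O)CN1CCC(c2cc3c(-c4ccc(=O)n(CC5CCOCC5)c4)ccnc3[nH]2)CC1` has not yet been measured. It differs from compound 1 by oxan-4-yl in place of hydrogen on a saturated chain carbon bound to an aromatic nitrogen. Going by the values given here, no measured step touches this place, since each of them replaced the ring rather than a group attached to it, so they give only loose guidance. A modest rise is therefore expected, an at least 2.0-fold higher number from compound 1 to compound 4 (0.30 log units; that floor lies within the scatter), with a wide range. For compound 4 the estimated value in this assay is 6 uL/min, expected to fall between 2 uL/min and 18 uL/min.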

Compound 4, intrinsic clearance in a liver preparation (reported as CLH), per the amount of preparation that the assay uses: 20 uL/min
Compound 4: the middle estimate sits 3.3-fold (0.52 log units) below what was measured; the whole stated range lies below it.
By their numbers in this assay, from the lowest: compounds 2, 4 and 3 (each within the scatter of the next). At a limit, below all of these: compound 1.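

Every earlier step replaced the whole ring, so none could show what a group attached to that ring does on its own. Here the ring stays, and in this assay the change from methyl to (oxan-4-yl)methyl, on a saturated chain carbon bound to an aromatic nitrogen, is enough by itself to give an at least 6.6-fold higher number from compound 1 to compound 4 (0.82 log units; beyond the scatter). That step is only a floor, and its true size cannot be read, because compound 1 stands at a limit of the assay rather than at a number: the limit of < 3 uL/min in this assay, at which 1 of the 4 values shown sits.

The compounds shown do not separate the part played by the ring oxygen of oxan-4-yl from that of its added carbons, which a cyclohexylmethyl group at this place would help to test. They also leave open how clearance follows chain size here, from an ethyl group to a longer chain.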